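Changing the Acyl Group of an Aryl Ester

This account rests on a few compounds, and the source may have more. Where it says the series, first, only, none or still open, it means among the compounds named here.

Compound 3 `CCC(=O)Oc1cc(/C=C/C(=O)c2ccc(OC)c3c2OC(C)(C)C=C3)ccc1OC` carries a propanoyl on an oxygen of the shared core. In a functional assay on K562 cells (Homo sapiens) for cytotoxicity, read by MTT assay (on this read-out higher numbers stand for weaker inhibition and lower numbers for stronger inhibition), compound 3 gives 160 nM, the lowest of the two numbers in hand. Its nearest neighbour is compound 1 `COc1ccc(/C=C/C(=O)c2ccc(OC)c3c2OC(C)(C)C=C3)cc1O`, which in this assay gives 630 nM; the step of a 3.9-fold lower number from compound 1 to compound 3 (0.60 log units; beyond the scatter) came with propanoyl in place of hydrogen on an oxygen on an aromatic ring. Compound 2 `C=CCOc1cc(/C=C/C(=O)c2ccc(OC)c3c2OC(C)(C)C=C3)ccc1OC` reaches only a limit of this assay, > 10000 nM (the limit of > 10000 nM in this assay, at which 1 of the 3 values shown sits). The step of an at least 62-fold lower number from compound 2 to compound 3 (1.79 log units; beyond the scatter) followed propanoyl in place of allyl on an oxygen on an aromatic ring.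

Compound 4 `COc1ccc(/C=C/C(=O)c2ccc(OC)c3c2OC(C)(C)C=C3)cc1OC(=O)c1ccc(Br)cc1` keeps the ester and differs from compound 3 by 4-bromophenyl in place of ethyl on a carbonyl carbon. Among the measured compounds shown here, no measured step exchanges one acyl group for another; the two steps that end at compound 3 show only that the propanoyl ester is favoured over the free hydroxyl and over the allyl ether. With the ester linkage preserved, the account expects a step of a 1.9-fold higher number from compound 3 to compound 4 (0.27 log units; within the scatter) that stays close to the scatter, the number perhaps drifting upward. Compound 4 is therefore estimated at 300 nM, within 80 nM to 1200 nM.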

Compound 4, half-maximal inhibitory concentration: 1110 nM
Beside the measured number, compound 4's estimate is 3.7-fold (0.57 log units) below it, and the stated range covers the measured number.
By their numbers in this assay, from the lowest: compound 3; then compounds 1 and 4 (each within the scatter of the next). At a limit, above all of these: compound 2.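

Among the compounds shown here, this is the first exchange of one acyl group for another on this oxygen, and it shows that the ester linkage alone does not fix the number: a 6.9-fold higher number from compound 3 to compound 4 (0.84 log units; beyond the scatter) came with 4-bromophenyl in place of ethyl on a carbonyl carbon. The advantage that propanoyl held over the free hydroxyl does not carry over to the (4-bromophenyl)carbonyl ester, as a 1.8-fold higher number from compound 1 to compound 4 (0.25 log units; within the scatter) leaves the two compounds within the scatter of each other. The step of an at least 9.0-fold lower number from compound 2 to compound 4 (0.95 log units; beyond the scatter) still sets this ester apart from the allyl ether, though the value of compound 2 is a limit: the limit of > 10000 nM in this assay, at which 1 of the 4 values shown sits.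

Only two acyl groups are shown, so it remains open whether the step follows from the aromatic ring, from the bromine or from the larger size of the group. A plain benzoyl, an acetyl, a longer chain such as butanoyl or an acyl group bearing an amine would each bear on that question.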